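Replacing 1H-1,2,3-triazol-4-yl with fluoro on compound 3

This account rests on a few compounds, and the source may have more. Where it says the series, first, only, none or still open, it means among the compounds named here.

In a physicochemical assay for solubility, read by turbidimetry, measured as kinetic solubility, at pH 6.8 (a higher number here means a more soluble compound, a lower number a less soluble compound), compound 1 (`O=C(NCCCCn1cccn1)c1cccc(C2SCC(=O)N2c2ccccn2)c1`) gives 50000 nM and compound 2 (`Cc1ccnc(N2C(=O)CSC2c2cccc(C(=O)NCCCCn3cccn3)c2)c1`) gives 50000 nM. Compound 3 (`O=C(NCCCCc1ccccc1)c1cccc(C2SCC(=O)N2c2cccc(-c3c[nH]nn3)c2)c1`) gives 20000 nM, the lowest of these three numbers.

Compound 4 (`O=C(NCCCCc1ccccc1)c1cccc(C2SCC(=O)N2c2cccc(F)c2)c1`) has not yet been measured. It differs from compound 3 by one change: fluoro in place of 1H-1,2,3-triazol-4-yl on an aromatic carbon, meta to a large group (fluoro in place of 1H-1,2,3-triazol-4-yl on an aromatic carbon).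

Going by the values given here, only one measured step can be consulted, no change at the digits printed from compound 1 to compound 2 (within the scatter). That step puts methyl in place of hydrogen, a much smaller swap in a different place, so it offers only weak guidance. Among the compounds with values here, no measured pair isolates the group that leaves here, which makes the direction a cautious judgement rather than a trend. A modest fall in this assay is expected, though no real change remains possible. The expected change is a 2.0-fold lower number from compound 3 to compound 4 (0.30 log units; within the scatter), an estimate with a wide margin. Compound 4 is estimated at 10000 nM, with an expected range from 3000 nM to 30000 nM.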

Compound 4, solubility: 10000 nM
Beside the measured number, compound 4's estimate shows no gap at the digits printed; measured number inside the range.
By their numbers in this assay, from the lowest: compounds 4 and 3 (each within the scatter of the next); then compounds 1 and 2 (each within the scatter of the next).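

Going by these compounds alone, this is the first measured step at this place, an aromatic carbon of a six-membered aromatic ring of carbon only, meta to a large group; the only earlier step put methyl in place of hydrogen elsewhere on a different compound. In this assay, fluoro in place of 1H-1,2,3-triazol-4-yl gives a 2.0-fold lower number from compound 3 to compound 4 (0.30 log units; within the scatter), so a five-membered aromatic ring carrying a hydrogen-bond donor and acceptors can give way to a single fluorine atom with a step that stays inside the usual scatter. No measurement shown here offers an explanation for this step.

As far as these compounds go, whether an amine or a carboxylic acid on this same carbon would give a step beyond the scatter remains open. Also open, from the compounds shown here alone, is whether this swap would read the same with a shorter chain on the amide.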